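Swapping a Methyl for Hydrogen on the Ring Nitrogen

The source may hold more compounds than are shown below. What is called first, only, known or untested is meant among the compounds shown, and "the series" means these compounds.

Compound 1 `Cn1c([N+](=O)[O-])cnc1C(=O)NCc1ccc(F)cc1`: 88%
Compound 2 `Cn1c([N+](=O)[O-])cnc1C(=O)NC1CCCCC1`: "not determined" (no result reported)

In an ADME assay on liver (Homo sapiens) for metabolic stability, read by LC-MS, using microsomes and NADPH, with a stated time of 2 h, tested at 5 uM (a lower number here means that less of the compound is left, a higher number that more of the compound is left), compound 1 gives 88%, so most of it is left at the end of the test. Among the compounds with values here, it holds the only number available, because compound 2 has no reported result, and it therefore cannot be ranked against another compound. Compound 3 `O=C(NCc1ccc(F)cc1)c1ncc([N+](=O)[O-])[nH]1` differs from compound 1 in one place: hydrogen in place of methyl on an aromatic nitrogen. This puts hydrogen in place of methyl on an aromatic nitrogen. Within the data shown here, no measured pair shows the effect of such a swap, so no clear direction can be expected. The estimated step of a number 3 percentage points lower from compound 1 to compound 3 (within the scatter) stays within the usual scatter. For compound 3 the estimated value is 85%, with an expected range of 65% to 100%.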

Compound 3, percent of the compound remaining: 94%
Beside the measured number, compound 3's estimate is 9 percentage points below it, and the stated range covers the measured number.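

In this assay, within the data shown here, the first measured swap at this ring nitrogen, hydrogen in place of methyl on an aromatic nitrogen, gives a number 6 percentage points higher from compound 1 to compound 3 (within the scatter) and so leaves the read-out unchanged within normal variation. The methyl group is therefore not needed to keep most of the compound intact in this test. Nothing measured here explains this result.

The compounds shown leave open how a longer chain on this nitrogen, such as ethyl, would behave. They also leave open what an amine in place of the nitro group would do.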